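The source may report more compounds than this note shows. Statements on the series, on what has been measured and on what is new or still open speak of the compounds shown alone.

Measured so far:
Compound 1 `CCN1C(=O)N(CC)C2C1NC(=S)N2/N=C/C=C/c1ccccc1[N+](=O)[O-]`: in a functional assay on MCF7 cells (Homo sapiens) for inhibition, read by MTT assay, with a stated time of 72 h (a higher number here means a weaker inhibitor, a lower number a stronger inhibitor), compound 1 gives 43900 nM.
Compound 2 `CCN1C(=O)N(CC)C2C1NC(=S)N2/N=C/C=C/c1ccccc1OC`: in this assay compound 2 reaches only a limit, > 100000 nM.

Among the compounds with values here, compound 2 therefore stands at the limit of > 100000 nM in this assay, at which 1 of the 2 values shown sits, and the single measured step, an at least 2.2-fold higher number from compound 1 to compound 2 (0.35 log units; beyond the scatter), concerns a different change. Compound 3 `CCN1C(=O)N(CC)C2C1NC(=S)N2/N=C/C=C/c1ccc(OC)cc1` differs from compound 2 by 4-methoxyphenyl in place of 2-methoxyphenyl on a double-bonded chain carbon bound to a double-bonded chain carbon. No measured step moves a methoxy group from one ring carbon to another, so nothing shown points to a direction. Compound 3 is expected to stay close to compound 2, so the expected step is a number no higher from compound 2 to compound 3 (the limit leaves the size open). Compound 3 is estimated at 100000 nM, between 30000 nM and 300000 nM.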

Compound 3, half-maximal inhibitory concentration: 36600 nM
The estimate for compound 3 lay 2.7-fold (0.44 log units) above the measured number; measured number inside the range.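

In this assay moving the methoxy group on the ring gives an at least 2.7-fold lower number from compound 2 to compound 3 (0.43 log units; beyond the scatter) and so shows that the place of this group counts, which the earlier pair could not show. Compound 2 carries only a limit of the assay, so this step has no exact size: the limit of > 100000 nM in this assay, at which 1 of the 3 values shown sits. The change from the 2-nitrophenyl group gives a 1.2-fold lower number from compound 1 to compound 3 (0.08 log units; within the scatter) and so does not separate these two rings here.

On these data alone, whether an amine or a carboxylic acid in place of the methoxy group would shift the number stays open.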